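Fluorine on the phenyl of a triazole-bearing core

This account rests on a few compounds, and the source may have more. Where it says the series, first, only, none or still open, it means among the compounds named here.

Compound 3 `C=C1C[C@]23C[C@@]1(O)CC[C@H]2c1ccc(O)c(C)c1[C@@H]3Cn1cc(-c2ccccc2)nn1` is the reference point. In a functional assay on SW480 cells (Homo sapiens) for cytotoxicity, read by MTT assay, with a stated time of 4 days (on this read-out lower numbers stand for stronger inhibition and higher numbers for weaker inhibition), compound 3 gives > 20000 nM, which is a limit of the assay rather than a measured number. Two close relatives are known from the same test. Compound 1 `C=C1C[C@]23C[C@@]1(O)CC[C@H]2c1ccc(O)c(C)c1[C@@H]3Cn1cc(-c2ccc(OC)cc2)nn1` carries a methoxy on the phenyl ring; in this assay compound 1 gives > 20000 nM, again only a limit. Compound 2 `C=C1C[C@]23C[C@@]1(O)CC[C@H]2c1cc(Br)c(O)c(C)c1[C@@H]3Cn1cc(-c2ccc(F)cc2)nn1` carries both a bromo on the shared core and a fluoro on the phenyl; in this assay compound 2 gives > 20000 nM, once more a limit. For the measured compounds named here, the one step between measured compounds, a step that the two limits leave unreadable from compound 1 to compound 3, cannot be sized because of the limit of > 20000 nM in this assay, at which 3 of the 3 values shown sit. Compound 4 `C=C1C[C@]23C[C@@]1(O)CC[C@H]2c1ccc(O)c(C)c1[C@@H]3Cn1cc(-c2ccc(F)cc2)nn1` differs from compound 3 by fluoro in place of hydrogen on an aromatic carbon. Going by the values given here, no measured step gives its size, and every neighbour sits at the same limit. The step from compound 3 to compound 4 is expected to be a step that the limit leaves unreadable from compound 3 to compound 4. Compound 4 is therefore estimated at 30000 nM, within 10000 nM to 100000 nM, most likely reported again only as a limit.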

Compound 4, half-maximal inhibitory concentration: > 20000 nM
Compound 4: a limit, no number; the forecaster's own chance of this, stated with the estimate: 85%; the middle value lies beyond the limit too.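

Compound 4 sits at a limit of the assay, as do compound 1, compound 2 and compound 3, so no step to compound 4 can be read: the limit of > 20000 nM in this assay, at which 4 of the 4 values shown sit.

The compounds shown leave open how strongly any of the four acts in this assay, and whether fluoro, methoxy or bromo changes that at all.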